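Series notes: amide aryl swap on the sulfonamide core

This account rests on a few compounds, and the source may have more. Where it says the series, first, only, none or still open, it means among the compounds named here.

Three compounds sharing the core of compound 1 `O=C(Nc1ccc(S(=O)(=O)Nc2ccccc2)cc1)c1ccc(I)cc1F` have been measured in a functional assay on HEK293 cells for agonist activity at probable G-protein coupled receptor 27 (Homo sapiens), read by a luciferase reporter and beta-arrestin recruitment, with a stated time of 10 min; a higher number here means that more compound is needed for the effect, a lower number that less compound is needed. Compound 1 gives 5130 nM. Compound 2 `Cc1cc(Cl)ccc1C(=O)Nc1ccc(S(=O)(=O)Nc2ccccc2)cc1` gives 912 nM, and compound 3 `O=C(Nc1ccc(S(=O)(=O)Nc2ccccc2)cc1)c1ccc(Cl)nc1F` gives 2290 nM. On these numbers compound 3 stands second highest of the three, nearer to compound 1 than to compound 2. Compound 4 `COc1cc(Br)ccc1C(=O)Nc1ccc(S(=O)(=O)Nc2ccccc2)cc1` is the next member and differs from compound 3 in one place: 4-bromo-2-methoxyphenyl in place of 6-chloro-2-fluoropyridin-3-yl on a carbonyl carbon. Going by the values given here, two measured steps bear on this change. The step of a 5.6-fold lower number from compound 1 to compound 2 (0.75 log units; beyond the scatter) shows that moving from 2-fluoro-4-iodophenyl to 4-chloro-2-methylphenyl gave a clearly lower number, and the step of a 2.5-fold higher number from compound 2 to compound 3 (0.40 log units; beyond the scatter) shows that the 6-chloro-2-fluoropyridin-3-yl of compound 3 gave a higher number than the carbon-only ring of compound 2. Returning to a carbon-only ring in compound 4, now as 4-bromo-2-methoxyphenyl, is therefore expected to lower the number by a modest amount. The expected step is a 1.9-fold lower number from compound 3 to compound 4 (0.28 log units; within the scatter). For compound 4 the estimate in this assay is 1200 nM, expected to lie between 500 nM and 3000 nM.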

Compound 4, half-maximal effective concentration: 1020 nM
For compound 4 the middle estimate is 1.2-fold (0.07 log units) above the measured one, and the stated range covers the measured number.
By their numbers in this assay, from the lowest: compounds 2 and 4 (each within the scatter of the next); then compound 3; then compound 1.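

A second carbon-only ring at this place, on a carbonyl carbon whose other neighbour is the amide-type nitrogen, again gives a lower number than 6-chloro-2-fluoropyridin-3-yl, with a 2.2-fold lower number from compound 3 to compound 4 (0.35 log units; beyond the scatter). The two rings of compounds 2 and 4 cannot be told apart, with a 1.1-fold higher number from compound 2 to compound 4 (0.05 log units; within the scatter), so 4-bromo-2-methoxyphenyl and 4-chloro-2-methylphenyl serve equally well here. A carbon-only ring alone does not settle the number, since compound 1 goes against that reading, with a 5.0-fold lower number from compound 1 to compound 4 (0.70 log units; beyond the scatter); no measurement shown explains these differences.

Bromine and methoxy enter together in compound 4, so their separate shares in the number remain open. Also open, as far as these compounds go, is how the number responds to an amine or a carboxylic acid on this ring.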